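Methoxy-to-methyl swap on the nucleoside core: cytotoxicity notes

The source may hold more compounds than are shown below. What is called first, only, known or untested is meant among the compounds shown, and "the series" means these compounds.

Measured so far:
- compound 1 `COc1ncnc2c1c(-c1ccsc1)cn2[C@@H]1O[C@H](CO)[C@@H](O)[C@H]1O`: 75300 nM
- compound 2 `COc1nc(N)nc2c1c(-c1ccsc1)cn2[C@@H]1O[C@H](CO)[C@@H](O)[C@H]1O`: > 100000 nM
- compound 3 `COc1ncnc2c1c(-c1ccccc1)cn2[C@@H]1O[C@H](CO)[C@@H](O)[C@H]1O`: > 100000 nM

Going by the values given here, in an ADME assay on MRC5 cells (Homo sapiens), read by MTT assay, with a stated time of 72 h (on this read-out lower numbers stand for stronger inhibition and higher numbers for weaker inhibition), compound 1 gives 75300 nM and is the only compound of the three with a number rather than a limit. For compound 2 the value > 100000 nM is a limit of the assay. For compound 3 the value > 100000 nM is likewise a limit. The two measured steps, an at least 1.3-fold higher number from compound 1 to compound 2 (0.12 log units; that floor lies within the scatter) and an at least 1.3-fold higher number from compound 1 to compound 3 (0.12 log units; that floor lies within the scatter), therefore only set a floor, and that floor lies within the scatter; both end at the limit of > 100000 nM in this assay, at which 2 of the 3 values shown sit.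

Compound 4 `Cc1ncnc2c1c(-c1ccsc1)cn2[C@@H]1O[C@H](CO)[C@@H](O)[C@H]1O` differs from compound 1 by methyl in place of methoxy on an aromatic carbon. Neither measured step touches the methoxy group, so nothing here bears directly on this change; the whole series sits at weak inhibition, with two of three values at the limit. For compound 4 no step beyond the scatter is expected, and its value is estimated as 80000 nM (range 35000 nM to 180000 nM). This estimate means an expected step of a 1.1-fold higher number from compound 1 to compound 4 (0.03 log units; within the scatter), with a fair chance that only a limit is reported.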

Compound 4, half-maximal inhibitory concentration: > 100000 nM
Compound 4 was reported as a limit; the forecaster's own chance of this, stated with the estimate: 45%; at least 1.2-fold (0.09 log units) between middle value and limit.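

In this assay, going by these compounds alone, the methoxy group now has a direct reading for the first time: methyl in place of methoxy gives an at least 1.3-fold higher number from compound 1 to compound 4 (0.12 log units; that floor lies within the scatter). Compound 4 gives > 100000 nM, which is a limit of the assay and not a number. This change can therefore be read only as a floor, as with the amino and phenyl changes, and no actual size can be assigned to it: the limit of > 100000 nM in this assay, at which 3 of the 4 values shown sit.

Going by these compounds, how an amine, a chlorine or a longer alkoxy chain on this aromatic carbon would read in this assay stays open. Within the data shown here, with compound 1 the only compound that has a number, it is also open whether methyl reaches far past the limit or sits just beyond it, and whether any group here gives a clearly lower number.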